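Removing the Chloro Group from Compound 3

A few compounds are considered here, and "the series" means these few. Any claim that something is new, unique, unknown or untested is made for them only; others in the source may bear on it.

Of the compounds shown here, three sharing one core have been measured in a functional assay on A549 cells (Homo sapiens) for antiproliferative activity, read by MTT assay, with a stated time of 24 h; a higher number here means a weaker inhibitor, a lower number a stronger inhibitor. Compound 1 `COc1ccc(C(=O)/C=C/c2cc(-c3ccc(OC)c(OC)c3)n3nc(-c4ccccc4)cc3n2)cc1OC` gives 3900 nM, compound 2 `COc1ccc(C(=O)/C=C/c2cc(-c3ccc(OC)c(OC)c3)n3nc(-c4ccccc4)cc3n2)cc1` gives 11900 nM, and compound 3 `COc1ccc(-c2cc(/C=C/C(=O)c3ccc(Cl)cc3)nc3cc(-c4ccccc4)nn23)cc1OC` gives 15400 nM. Compound 3 therefore has the highest number of the three; it sits close to compound 2, since a 1.3-fold higher number from compound 2 to compound 3 (0.11 log units; within the scatter), but clearly apart from compound 1, since a 3.9-fold higher number from compound 1 to compound 3 (0.60 log units; beyond the scatter).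

Compound 4 `COc1ccc(-c2cc(/C=C/C(=O)c3ccccc3)nc3cc(-c4ccccc4)nn23)cc1OC` differs from compound 3 in one place: hydrogen in place of chloro on an aromatic carbon. Going by the values given here, no measured step removes exactly this group, so the expectation leans on neighbouring steps. Removing a methoxy group elsewhere produced a 3.1-fold higher number from compound 1 to compound 2 (0.48 log units; beyond the scatter), a modest loss, while swapping methoxy for chloro on the carbonyl-bearing ring gave a 1.3-fold higher number from compound 2 to compound 3 (0.11 log units; within the scatter), nothing beyond the scatter. Taken together these suggest that stripping the chloro group is unlikely to recover potency and may cost a little; a step of a 1.3-fold higher number from compound 3 to compound 4 (0.11 log units; within the scatter) is expected. Compound 4 is therefore estimated at 20000 nM, with a plausible range from 8000 nM to 45000 nM in this assay.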

Compound 4, half-maximal inhibitory concentration: 10700 nM
Estimate against measurement, compound 4: 1.9-fold (0.27 log units) above; low and high end bracket the measured number.
By their numbers in this assay, from the lowest: compound 1; then compounds 4, 2 and 3 (each within the scatter of the next).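

In this assay, going by these compounds alone, the change from 4-chlorophenyl to phenyl gives a 1.4-fold lower number from compound 3 to compound 4 (0.16 log units; within the scatter), and the change from the single methoxy of compound 2 to the same plain phenyl gives a 1.1-fold lower number from compound 2 to compound 4 (0.05 log units; within the scatter), so chloro, methoxy and hydrogen on this aromatic carbon cannot be told apart. Only the 3,4-dimethoxyphenyl of compound 1 stands clear of the plain phenyl, with a 2.7-fold higher number from compound 1 to compound 4 (0.44 log units; beyond the scatter), which means that among these compounds a single methoxy group on this ring is not enough to separate from hydrogen, while two are. Nothing given here accounts for these numbers.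

As far as these compounds go, it remains open whether a different kind of group on this aromatic carbon, such as an amine or a carboxylic acid, would move the number beyond the scatter. From the compounds shown here alone, it is also open whether a third methoxy group on this ring would take the number lower than in compound 1.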